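This account rests on a few compounds, and the source may have more. Where it says the series, first, only, none or still open, it means among the compounds named here.

Compounds measured so far:

- Compound 1, `O=C(CCCCCCc1ccccc1C(=O)O)c1ncc(-c2ccccn2)o1`, > 600 nM
- Compound 2, `O=C(CCCCCCc1ccccn1)c1ncc(-c2ccccn2)o1`, 120 nM
- Compound 3, `O=C(CCCCCCc1ccc(Cl)cc1)c1ncc(-c2ccccn2)o1`, 2.7 nM

All three share one core and differ only in the ring at the end of the saturated chain. In an assay for inhibition of Fatty-acid amide hydrolase 1 (Rattus norvegicus) (a lower number here means a stronger inhibitor, a higher number a weaker inhibitor), compound 1 reaches only (the limit of > 600 nM in this assay, at which 1 of the 3 values shown sits), which is a limit of the measurement and not a number. Compound 2 gives 120 nM in this assay, and compound 3 gives 2.7 nM, the lowest of the two numbers obtained. The step of a 44-fold lower number from compound 2 to compound 3 (1.65 log units; beyond the scatter) is large, and the step of an at least 220-fold lower number from compound 1 to compound 3 (2.34 log units; beyond the scatter) is at least as large, so the 4-chlorophenyl end of compound 3 stands well apart from the other two ends.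

Compound 4, `CC(C)(C)OC(=O)Nc1ccc(CCCCCCC(=O)c2ncc(-c3ccccn3)o2)cc1`, keeps everything of compound 3 except for one change: (tert-butoxycarbonyl)amino in place of chloro on an aromatic carbon, placed on an aromatic carbon of a six-membered aromatic ring of carbon only, para to a large group. Among the measured compounds shown here, none of the measured steps changes a substituent on the 4-chlorophenyl ring itself; they exchange the whole ring, so they speak only indirectly to this step. A modest loss in this assay is expected, with the step of a 5.6-fold higher number from compound 3 to compound 4 (0.74 log units; beyond the scatter). Compound 4 is estimated at 15 nM, between 3 nM and 70 nM.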

Compound 4, inhibition constant: 5.6 nM
Compound 4: the middle estimate sits 2.7-fold (0.43 log units) above what was measured; the measured number falls inside the stated range.
By their numbers in this assay, from the lowest: compound 3; then compound 4; then compound 2. At a limit, above all of these: compound 1.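

Among the compounds shown, this is the only change on the 4-chlorophenyl ring itself and not an exchange of the whole ring, and in this assay it costs little: a 2.1-fold higher number from compound 3 to compound 4 (0.32 log units; beyond the scatter). Among the compounds shown here, that step is far smaller than the one that swaps the ring, a 44-fold lower number from compound 2 to compound 3 (1.65 log units; beyond the scatter), so this aromatic carbon takes the much larger (tert-butoxycarbonyl)amino group, with its added hydrogen-bond donor and acceptors, in place of chloro at only a modest loss. Nothing measured here explains why the loss is this small.

With only these two groups at this place, no trend with group size can be drawn. A free amine or a carboxylic acid on this carbon remains an open case, and so does a longer chain carrying the same substituted ring.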